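Working notes: tert-butyl in place of trifluoromethoxy

A few compounds are considered here, and "the series" means these few. Any claim that something is new, unique, unknown or untested is made for them only; others in the source may bear on it.

- Compound 1 `Cc1cc(NC(=O)Nc2cccc(C(N)=O)c2)c2ccccc2n1`: > 25000 nM (a limit, not a number)
- Compound 2 `Cc1cc(NC(=O)Nc2cccc(OC(F)(F)F)c2)c2ccccc2n1`: 13000 nM

All values come from an ADME assay on HepG2 cells (Homo sapiens) for cytotoxicity, with a stated time of 72 h; a lower number here means that less compound is needed, a higher number that more compound is needed for the effect. In this assay, within the data shown here, compound 2 gives 13000 nM, the only actual number so far. Compound 1 is reported only as a limit, > 25000 nM.

Compound 3 `Cc1cc(NC(=O)Nc2cccc(C(C)(C)C)c2)c2ccccc2n1` carries tert-butyl in place of trifluoromethoxy on an aromatic carbon, meta to a large group: tert-butyl in place of trifluoromethoxy on an aromatic carbon. Among the measured compounds shown here, one measured step bears on this change, since it also alters this substituent: an at least 1.9-fold lower number from compound 1 to compound 2 (0.28 log units; that floor lies within the scatter). That step is only a floor and gives no size to carry over, so no step beyond the scatter is expected in this assay, and no direction can be favoured. The expected result is a 1.1-fold lower number from compound 2 to compound 3 (0.03 log units; within the scatter). For compound 3 the estimated value is 12000 nM, with an expected range of 6000 nM to 25000 nM.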

Compound 3, half-maximal effective concentration: > 25000 nM
Compound 3: no number, only a limit (the forecaster's own chance of this, stated with the estimate: 20%); middle value at least 2.0-fold (0.31 log units) away from the limit.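

In this assay, tert-butyl in place of trifluoromethoxy on this aromatic carbon gives an at least 1.9-fold higher number from compound 2 to compound 3 (0.28 log units; that floor lies within the scatter), a floor rather than a measured size, so the true step may be larger or may stay within the scatter. Among these compounds, compound 2 remains the only compound with an actual number, while the carbamoyl of compound 1 and the tert-butyl of compound 3 both end at the same limit, and the step between those two compounds cannot be read. At this position, then, the read-out is capped for two of the three groups, which restricts what the series can show so far: the limit of > 25000 nM in this assay, at which 2 of the 3 values shown sit.

The order of the three groups therefore stays unresolved. From the compounds shown here alone, it also remains open whether an amine, a carboxylic acid or a longer chain at this position would give a number or reach the same limit.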